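The source may report more compounds than this note shows. Statements on the series, on what has been measured and on what is new or still open speak of the compounds shown alone.

Of the compounds shown here, three that share one core have been measured in a functional assay on the whole organism for inhibition, with Nicotiana tabacum as the target; on this read-out higher numbers stand for weaker inhibition and lower numbers for stronger inhibition. Compound 1 `Cc1nc2nccc-2c(NC(C)C)[nH]1` gives 550000000 nM. Compound 2 `Cc1nc2nccc-2c(NCC(C)O)[nH]1` gives 30200000 nM. Compound 3 `COCCNc1[nH]c(C)nc2nccc1-2` gives 166000000 nM, the second highest of the three numbers, with compound 1 nearest above it and compound 2 furthest below it. Compound 4 `Cc1nc2nccc-2c(NCC(C)C)[nH]1` differs from compound 3 by isopropyl in place of methoxymethyl on a saturated chain carbon bound to a nitrogen on an aromatic ring. Going by the values given here, two measured steps bear on this change. The step of a 3.3-fold lower number from compound 1 to compound 3 (0.52 log units; beyond the scatter) shows that bringing in 2-methoxyethyl in place of isopropyl lowered the number, and the step of a 5.5-fold higher number from compound 2 to compound 3 (0.74 log units; beyond the scatter) shows that methoxymethyl in place of 1-hydroxyethyl raised it. Removing the oxygen altogether is therefore expected to raise the number again, by a step of a 2.4-fold higher number from compound 3 to compound 4 (0.38 log units; beyond the scatter). Compound 4 is thus estimated at 400000000 nM, with a range from 150000000 nM to 1200000000 nM.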

Compound 4, half-maximal inhibitory concentration: 38900000 nM
Estimate against measurement, compound 4: 10-fold (1.01 log units) above; the whole stated range lies above it.
By their numbers in this assay, from the lowest: compounds 2 and 4 (each within the scatter of the next); then compound 3; then compound 1.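

The oxygen turns out not to be needed for a low number: isobutyl in place of 2-methoxyethyl gives a 4.3-fold lower number from compound 3 to compound 4 (0.63 log units; beyond the scatter). Methyl in place of hydroxy gives a 1.3-fold higher number from compound 2 to compound 4 (0.11 log units; within the scatter), so at this place the two cannot be told apart. Isobutyl in place of isopropyl on the nitrogen gives a 14-fold lower number from compound 1 to compound 4 (1.15 log units; beyond the scatter), which shows that the chain's shape alone can move the number a long way, with no oxygen involved.

No measurement shown explains these steps. On these data alone, whether an amine, a carboxylic acid or a longer chain at this place would keep the number as low remains open.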